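The source may hold more compounds than are shown below. What is called first, only, known or untested is meant among the compounds shown, and "the series" means these compounds.

Measured so far:
compound 1 `Cc1ccc(CNC(=O)c2cccc(C(C)Oc3cccnc3Nc3ncccn3)c2)cc1`, > 100000 nM in a functional assay on HCC78 cells (Homo sapiens) for antiproliferative activity, read by MTT assay, with a stated time of 48 h; on this read-out lower numbers stand for stronger inhibition and higher numbers for weaker inhibition
compound 2 `Cc1ccc(CNC(=O)c2cccc(C(C)Oc3ccnc(NN4CCOCC4)c3)c2)cc1`, 68300 nM

In this assay compound 1 gives > 100000 nM, which is a limit of the assay and not a number (the limit of > 100000 nM in this assay, at which 1 of the 2 values shown sits). Compound 2, with 68300 nM, therefore holds the only number shown. Compound 3 `Cc1ccc(CNC(=O)c2cccc(C(C)Oc3ccnc(Nc4nc5ccccc5[nH]4)c3)c2)cc1` carries 1H-benzimidazol-2-yl in place of morpholin-4-yl on a nitrogen on an aromatic ring. Going by the values given here, no measured step covers this change, so the expectation leans on compound 2 alone. A modest gain in inhibition beyond the scatter is expected, giving a 2.3-fold lower number from compound 2 to compound 3 (0.36 log units; beyond the scatter), with the estimate for compound 3 at 30000 nM, ranging from 8000 nM to 100000 nM.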

Compound 3, half-maximal inhibitory concentration: > 100000 nM
Compound 3 ended at the assay's limit (the forecaster's own chance of this, stated with the estimate: 25%); middle value at least 3.3-fold (0.52 log units) away from the limit.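

Putting 1H-benzimidazol-2-yl in place of morpholin-4-yl on this nitrogen brings no gain in this assay; the change gives an at least 1.4-fold higher number from compound 2 to compound 3 (0.16 log units; that floor lies within the scatter). The value of compound 3 is a limit of the assay and not a number, so this step sets only a floor and cannot show a true loss. Limits now outnumber measured values in this small set: the limit of > 100000 nM in this assay, at which 2 of the 3 values shown sit.

On these data alone, how far compound 3 truly lies from compound 2 stays open. So does whether a phenyl ring or a simple methyl group on this nitrogen would give a lower number.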